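The compounds below may be only part of what the source reports. "The series", "measured", "known", "first", "only" and "open" are said of these compounds alone.

Measured in a functional assay on HT-29 cells (Homo sapiens) for cytotoxicity; a lower number here means a stronger inhibitor, a higher number a weaker inhibitor:
- Compound 1 `COc1ccc(S(=O)(=O)N2CCc3cccc(NC(=O)c4cccs4)c32)cc1` gives 37 nM
- Compound 2 `COc1ccc(S(=O)(=O)N2CCc3cccc(NC(=O)c4ccc(F)cc4)c32)cc1` gives 55 nM
- Compound 3 `COc1ccc(S(=O)(=O)N2CCc3cccc(NC(C)=O)c32)cc1` gives 51 nM

Compound 3, at 51 nM, cannot be separated from the other two measured compounds. The data show a 1.1-fold lower number from compound 2 to compound 3 (0.03 log units; within the scatter) and a 1.4-fold higher number from compound 1 to compound 3 (0.14 log units; within the scatter).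

Compound 4 `COc1ccc(S(=O)(=O)N2CCc3cccc(NCc4ccccc4)c32)cc1` carries benzyl in place of acetyl on a nitrogen on an aromatic ring. Cut one bond further out, the same difference reads acetamido to benzylamino.

For the measured compounds named here, three measured steps bear on this change, and each only in part. All of them swap the group on a carbonyl carbon: a 1.5-fold higher number from compound 1 to compound 2 (0.17 log units; within the scatter), a 1.4-fold higher number from compound 1 to compound 3 (0.14 log units; within the scatter) and a 1.1-fold lower number from compound 2 to compound 3 (0.03 log units; within the scatter). Since the last of these replaces a ring-bearing group with methyl and stays within the scatter, the arrival of a ring in compound 4 gives no reason on its own to expect a shift. The carbonyl, however, is kept in all three measured compounds and is lost in compound 4, so no measurement here tests its removal. A moderate move towards a higher number, meaning a weaker inhibitor, is therefore expected in this assay, though with wide uncertainty. The expected change is a 2.4-fold higher number from compound 3 to compound 4 (0.37 log units; beyond the scatter). Compound 4 is estimated at 120 nM, with an expected range of 30 nM to 600 nM.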

Compound 4, half-maximal inhibitory concentration: > 10000 nM
Compound 4: only a limit was reported (the forecaster's own chance of this, stated with the estimate: 5%); at least 83-fold (1.92 log units) between middle value and limit.
By their numbers in this assay, from the lowest: compounds 1, 3 and 2 (each within the scatter of the next). At a limit, above all of these: compound 4.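

In this assay, compound 4 is reported only as a limit of the assay, not as a number: the limit of > 10000 nM in this assay, at which 1 of the 4 values shown sits.

The three compounds with a carbonyl on this nitrogen lie within the scatter of one another, yet swapping that carbonyl-bearing group for benzyl gives an at least 190-fold higher number from compound 3 to compound 4 (2.29 log units; beyond the scatter), an at least 180-fold higher number from compound 2 to compound 4 (2.25 log units; beyond the scatter) and an at least 270-fold higher number from compound 1 to compound 4 (2.43 log units; beyond the scatter). The earlier compounds shown here showed that this position accepts methyl, thiophen-2-yl or 4-fluorophenyl on the carbonyl carbon; compound 4 shows that this freedom does not extend to the change from an amide to benzylamino. Compound 2 also carries a six-membered aromatic ring and still sits with compounds 1 and 3, so the ring on its own does not go with the large step, although compound 2 and compound 4 also differ by the fluorine.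

On these data alone, what remains open is whether the loss follows from removing the carbonyl or from benzyl itself. A free amine or a small methylamino group on this nitrogen would help to separate the two, and a sulfonamide there would test whether a group other than a carbonyl can take its place.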